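Z to E at the double bond of compound 2

The compounds below may be only part of what the source reports. "The series", "measured", "known", "first", "only" and "open" are said of these compounds alone.

Going by the values given here, in a functional assay on MDA-MB-231 cells (Homo sapiens) for antiproliferative activity, read by sulforhodamine B assay, with a stated time of 72 h (on this read-out lower numbers stand for stronger inhibition and higher numbers for weaker inhibition), only two compounds have numbers so far. Compound 1 `FC(F)(F)c1ccc(/C=C\c2cc3ccccc3nc2Cl)cc1` gives 5360 nM, and compound 2 `COc1ccc2nc(Cl)c(/C=C\c3ccc(C(F)(F)F)cc3)cc2c1` gives 22800 nM. Compound 2 therefore holds the higher of the two numbers, the weaker result of the pair.

Compound 3 `COc1ccc2nc(Cl)c(/C=C/c3ccc(C(F)(F)F)cc3)cc2c1` is still unmeasured. Its relation to compound 2 is this: the two compounds have the same atoms and bonds and differ only in configuration as drawn: 1 of 1 stereo elements differ; a double bond is drawn Z in compound 2 and E in compound 3. A double bond is drawn Z in compound 2 and E in compound 3, and nothing else changes.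

Among the compounds with values here, no measured pair tests this configuration. Within the data shown here, the only measured step, a 4.3-fold higher number from compound 1 to compound 2 (0.63 log units; beyond the scatter), is a methoxy in place of hydrogen on an aromatic carbon. That is a different kind of change, so it offers a rough scale of size and no direction. In this assay no step beyond the scatter is therefore expected, with a slight lean to a higher number held only tentatively. The expected step is a 1.3-fold higher number from compound 2 to compound 3 (0.12 log units; within the scatter). For compound 3 the estimated value is 30000 nM, with an expected range of 9000 nM to 90000 nM.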

Compound 3, half-maximal inhibitory concentration: 48800 nM
For compound 3 the middle estimate is 1.6-fold (0.21 log units) below the measured one; measured number inside the range.
By their numbers in this assay, from the lowest: compound 1; then compound 2; then compound 3.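

In this assay, the switch from Z to E at the double bond gives a 2.1-fold higher number from compound 2 to compound 3 (0.33 log units; beyond the scatter), which provides the first measured test of this configuration in the series and shows that it can move the number on its own. The direction favours the Z compound within this pair, as the E form gives the weaker inhibition, although the step is modest and this is a single pair carrying the methoxy group. The step can be assigned to the double bond alone, because no atom or bond changes between the two structures: the fact that compounds 2 and 3 differ only in the configuration as drawn

Still open, from the compounds shown here alone, is whether the same preference for Z holds on the core of compound 1, which carries hydrogen in place of the methoxy group, so the result cannot yet be treated as a general rule for the series. Also open, going by these compounds, is what an amine or a carboxylic acid in place of the trifluoromethyl group would do to the numbers, and whether the order of Z and E would survive that replacement.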